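Nitro in Place of Fluoro on the Shared Core

The source may report more compounds than this note shows. Statements on the series, on what has been measured and on what is new or still open speak of the compounds shown alone.

Of the compounds shown here, three built on one core have been tested in an ADME assay on HepG2 cells (Homo sapiens) for cytotoxicity, read by MTT assay, with a stated time of 7 days; a higher number here means a weaker inhibitor, a lower number a stronger inhibitor. In this assay compound 1 `O=C(c1cccnc1)N1N=C(c2ccc(O)cc2)CC1c1ccc(F)cc1` gives 52400 nM, the highest of the three numbers, though its distance to the other two is small. Compound 2 `COc1ccc(C2CC(c3ccc(O)cc3)=NN2C(=O)c2cccnc2)cc1C` gives 44800 nM in this assay, and compound 3 `COc1ccc(C2CC(c3ccc(O)cc3)=NN2C(=O)c2cccnc2)cc1` gives 42400 nM. The steps between them are a 1.2-fold lower number from compound 1 to compound 2 (0.07 log units; within the scatter), a 1.2-fold lower number from compound 1 to compound 3 (0.09 log units; within the scatter) and a 1.1-fold lower number from compound 2 to compound 3 (0.02 log units; within the scatter); none of the three reaches beyond the scatter, so the three numbers are best read as one level.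

Compound 4 `O=C(c1cccnc1)N1N=C(c2ccc(O)cc2)CC1c1ccc([N+](=O)[O-])cc1` differs from compound 1 in one place: nitro in place of fluoro on an aromatic carbon. The measured steps that bear on this change are the two that start from compound 1, since both alter the same aromatic carbon or the ring that carries it: a 1.2-fold lower number from compound 1 to compound 3 (0.09 log units; within the scatter) exchanges the fluoro for another group at that carbon, and a 1.2-fold lower number from compound 1 to compound 2 (0.07 log units; within the scatter) exchanges the whole ring. Both stayed within the scatter. Compound 4 is therefore expected to show no step beyond the scatter in this assay, a 1.0-fold lower number from compound 1 to compound 4 (0.02 log units; within the scatter). For compound 4 the estimate is 50000 nM, with a range from 25000 nM to 100000 nM.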

Compound 4, half-maximal inhibitory concentration: 18600 nM
Beside the measured number, compound 4's estimate is 2.7-fold (0.43 log units) above it; the whole stated range lies above it.
By their numbers in this assay, from the lowest: compound 4; then compounds 3, 2 and 1 (each within the scatter of the next).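

In this assay, within the data shown here, the change from 4-fluorophenyl to 4-nitrophenyl moves the number beyond the scatter (a 2.8-fold lower number from compound 1 to compound 4 (0.45 log units; beyond the scatter)), which no step among compound 1, compound 2 and compound 3 did. The separation is modest but appears from the other two compounds as well, both when nitro replaces methoxy (a 2.3-fold lower number from compound 3 to compound 4 (0.36 log units; beyond the scatter)) and when 4-nitrophenyl replaces 4-methoxy-3-methylphenyl (a 2.4-fold lower number from compound 2 to compound 4 (0.38 log units; beyond the scatter)), so at this position fluoro, methoxy and the methyl-bearing ring sit at one level while nitro stands apart from them. Nothing available offers an explanation for this separation.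

The compounds shown leave open whether the lower number is particular to nitro or would also appear with a nitrile, a trifluoromethyl group, a carboxylic acid or an amine on the same aromatic carbon. They also leave open whether nitro would give a similar step on another carbon of that ring, or whether the step would persist if the shared core were changed elsewhere.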